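Pyridin-2-yl on the oxadiazole carbon: compound 2 to 3

The source may report more compounds than this note shows. Statements on the series, on what has been measured and on what is new or still open speak of the compounds shown alone.

For the measured compounds named here, compound 1 `Cn1nnc(C(=O)CCCCCCc2ccccc2)n1` and compound 2 `O=C(CCCCCCc1ccccc1)c1ncno1` mark the series so far. In an assay on HEK-293T cells for inhibition of diacylglycerol lipase-alpha (Homo sapiens), read by colorimetric assay (a lower number here means a stronger inhibitor, a higher number a weaker inhibitor), compound 1 reaches only the limit > 10000 nM. In this assay compound 2 likewise reaches only the limit > 10000 nM; compound 2 thus stands at the limit of > 10000 nM in this assay, at which 2 of the 2 values shown sit. Going by the values given here, the single measured step, a step that the two limits leave unreadable from compound 1 to compound 2, gives no readable size. Compound 3 `O=C(CCCCCCc1ccccc1)c1nc(-c2ccccn2)no1` carries pyridin-2-yl in place of hydrogen on an aromatic carbon. Among the compounds with values here, no measured step bears on this change, so the expectation is wide, leaning toward a stronger inhibitor: compound 3 is estimated at 4000 nM, range 400 nM to 30000 nM, meaning an expected step of an at least 2.5-fold lower number from compound 2 to compound 3 (0.39 log units; beyond the scatter).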

Compound 3, half-maximal inhibitory concentration: 2750 nM
Estimate against measurement, compound 3: 1.5-fold (0.16 log units) above; low and high end bracket the measured number.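

For the compounds shown here, the aromatic carbon between two ring nitrogen atoms is the first place where a change gives a measurable inhibitor: pyridin-2-yl in place of hydrogen gives an at least 3.6-fold lower number from compound 2 to compound 3 (0.56 log units; beyond the scatter) in this assay. Going by these compounds, this step is a minimum, and its full size remains unknown. Compound 1 and compound 2 remain at a limit, not a number: the limit of > 10000 nM in this assay, at which 2 of the 3 values shown sit.

On these data alone, what phenyl or pyridin-4-yl would give on the same carbon remains open, so whether the pyridine nitrogen matters cannot be told. As far as these compounds go, the effect of a shorter chain on compound 3 is also open.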